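This account rests on a few compounds, and the source may have more. Where it says the series, first, only, none or still open, it means among the compounds named here.

Of the compounds shown here, three of a shared core have been measured in an assay on CHO cells for displacement of a labelled ligand from adenosine receptor A3 (Homo sapiens); a higher number here means a weaker inhibitor, a lower number a stronger inhibitor. Compound 1, `CNc1nc(Cl)nc2c1ncn2[C@@H]1O[C@H](C(=O)N2CCN(c3ccc(F)cc3)CC2)[C@@H](O)[C@H]1O`, gives 2690 nM there. Compound 2, `CCNC(=O)[C@H]1O[C@@H](n2cnc3c(NC4CC4)nc(Cl)nc32)[C@H](O)[C@@H]1O`, gives 0.676 nM. Compound 3, `CCNC(=O)[C@H]1O[C@@H](n2cnc3c(NCc4cccc(I)c4)nc(Cl)nc32)[C@H](O)[C@@H]1O`, gives 0.891 nM. On these numbers compound 3 stands second highest of the three; its nearest neighbour is compound 2, and the step of a 1.3-fold higher number from compound 2 to compound 3 (0.12 log units; within the scatter) lies within the scatter, while compound 1 stands far above both, beyond the scatter. Compound 1 differs from compound 3 in more than one place, so its gap to compound 3 cannot be tied to a single change.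

The next compound, compound 4, is `O=C(NC1CCC1)[C@H]1O[C@@H](n2cnc3c(NCc4cccc(I)c4)nc(Cl)nc32)[C@H](O)[C@@H]1O`. It differs from compound 3 by cyclobutyl in place of ethyl on an amide-type nitrogen. Among the compounds with values here, no measured step bears on this place: the one recorded step, from compound 2 to compound 3, concerns the nitrogen on the aromatic ring and was within the scatter, and compound 1 carries a different group on the same aromatic nitrogen as well as a different amide. Within the data shown here, the expectation for this assay therefore rests on no direct precedent, and a modest rise in the number, or none beyond the scatter, is estimated, as a 3.4-fold higher number from compound 3 to compound 4 (0.53 log units; beyond the scatter). Compound 4 is accordingly expected to give about 3 nM, within a range of 0.8 nM to 12 nM.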

Compound 4, inhibition constant: 18.2 nM
Estimate against measurement, compound 4: 6.1-fold (0.78 log units) below; measured number outside the range, above it.
By their numbers in this assay, from the lowest: compounds 2 and 3 (each within the scatter of the next); then compound 4; then compound 1.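

Within the data shown here, the amide-type nitrogen proves to be a sensitive place in this assay: cyclobutyl in place of ethyl gives a 20-fold higher number from compound 3 to compound 4 (1.31 log units; beyond the scatter), whereas the only earlier step between compounds differing in one place, a 1.3-fold higher number from compound 2 to compound 3 (0.12 log units; within the scatter), concerned the nitrogen on the aromatic ring and stayed within the scatter. The change takes 2 heavy atoms and no ring to 4 heavy atoms and one four-membered non-aromatic ring of carbon only, with the counts of hydrogen-bond donors and acceptors and the net charge the same on both sides, so this large step comes with a change in the carbon group alone. Nothing measured on these compounds accounts for the size of this step.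

A single step cannot separate the effect of the ring from that of the added carbons, and a straight propyl or butyl chain, or a cyclopropyl ring, on the same nitrogen would bear on that question. As far as these compounds go, it also remains open whether cyclobutyl would give a step of similar size with cyclopropyl rather than 3-iodobenzyl on the nitrogen on the aromatic ring, the pairing that compound 2 would provide as a reference.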